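Carbonyl substituent exchange at the side-chain ester position

A few compounds are considered here, and "the series" means these few. Any claim that something is new, unique, unknown or untested is made for them only; others in the source may bear on it.

Measured so far:
compound 1, `CCOC(=O)C[C@H]1[C@@H](O[Si](C)(C)C(C)(C)C)[C@H](n2cnc3c(NC(=O)Nc4ccccc4)ncnc32)O[C@@H]1COC(=O)NC`: 10.3 nM
compound 2, `CNC(=O)NC[C@H]1O[C@@H](n2cnc3c(NC(=O)Nc4ccccc4)ncnc32)[C@H](O[Si](C)(C)C(C)(C)C)[C@@H]1CC(=O)N(C)OC`: 12.7 nM

In a functional assay on SNB-75 cells (Homo sapiens) for antiproliferative activity (a lower number here means a stronger inhibitor of growth, a higher number a weaker inhibitor of growth), compound 1 gives 10.3 nM and compound 2 gives 12.7 nM. Compound 2 stands highest of the two numbers, but its nearest neighbour compound 1 sits within the scatter, so the two cannot be told apart on these data.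

Compound 3 `CCOC(=O)C[C@H]1[C@@H](O[Si](C)(C)C(C)(C)C)[C@H](n2cnc3c(NC(=O)Nc4ccccc4)ncnc32)O[C@@H]1CNC(=O)NC` has not been measured. Against compound 2 the change is ethoxy in place of methoxy(methyl)amino on a carbonyl carbon. Within the data shown here, no step between measured compounds is available, so nothing is known directly about what this change does. Among the measured compounds shown here, the only hint is that compound 1, which already carries the ethoxycarbonyl group, shows 10.3 nM and lies within the scatter of compound 2. The step is therefore expected to be a 1.2-fold lower number from compound 2 to compound 3 (0.06 log units; within the scatter), that is, none beyond the scatter. Compound 3 is estimated at 11 nM, with a range from 4 nM to 30 nM.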

Compound 3, concentration for 50% growth inhibition: 4.56 nM
The estimate for compound 3 lay 2.4-fold (0.38 log units) above the measured number, and the stated range covers the measured number.
By their numbers in this assay, from the lowest: compound 3; then compounds 1 and 2 (each within the scatter of the next).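

In this assay, ethoxy in place of methoxy(methyl)amino on the carbonyl carbon gives a 2.8-fold lower number from compound 2 to compound 3 (0.44 log units; beyond the scatter) with the (methylcarbamoyl)amino group held constant, so this carbonyl position does respond to the exchange. With ethoxycarbonyl held constant, (methylcarbamoyl)amino in place of (methylcarbamoyl)oxy gives a 2.3-fold lower number from compound 1 to compound 3 (0.35 log units; beyond the scatter) as a second single-place effect, whereas compounds 1 and 2 differ in both places and could not separate the two. Nothing at hand gives a reason for either step.

Open, going by these compounds, is how other carbonyl substituents on this side chain would read, such as a free carboxylic acid, a methylamino group or a longer alkoxy chain such as propoxy. Also open, on these data alone, is whether the ethoxy over methoxy(methyl)amino step holds when (methylcarbamoyl)oxy occupies the other place.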